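Methylation of the ring-amine nitrogen in the cinnamamide series

A few compounds are considered here, and "the series" means these few. Any claim that something is new, unique, unknown or untested is made for them only; others in the source may bear on it.

Within the data shown here, compound 1 `CCCc1cc(NC)c2cc(NC(=O)/C=C/c3ccc(C(F)(F)F)cc3)ccc2n1` is the reference point of the three measured members. In an assay on isolated protein for displacement of a labelled ligand from melanin-concentrating hormone receptor 1 (Homo sapiens) (a higher number here means a weaker inhibitor, a lower number a stronger inhibitor), compound 1 gives 1.5 nM, the lowest number of the set. Compound 3 `CCCc1cc(N)c2cc(NC(=O)/C=C/c3cccc(Cl)c3)ccc2n1` gives 1100 nM in this assay, and compound 2 `CCCc1cc(N)c2cc(NC(=O)CCc3ccccc3)ccc2n1` gives 8300 nM; both stand well beyond the scatter above compound 1, but each also differs from it in more than one place, so neither pair yields a clean step.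

Compound 4 `CCCc1cc(N(C)C)c2cc(NC(=O)/C=C/c3ccc(C(F)(F)F)cc3)ccc2n1` differs from compound 1 only by methyl in place of hydrogen on a nitrogen on an aromatic ring. Among the measured compounds shown here, no measured pair shows this exact change. A step beyond the scatter in this assay is expected from compound 1 to compound 4 toward a higher number, of moderate size: a 3.3-fold higher number from compound 1 to compound 4 (0.52 log units; beyond the scatter). Compound 4 is accordingly estimated at 5 nM, within 1.5 nM to 25 nM.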

Compound 4, half-maximal inhibitory concentration: 43 nM
Compound 4: the middle estimate sits 8.6-fold (0.93 log units) below what was measured; measured number above the stated range.
By their numbers in this assay, from the lowest: compound 1; then compound 4; then compound 3; then compound 2.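

Methylamino to dimethylamino is the first single-place change read in this series, and in this assay it gives a 29-fold higher number from compound 1 to compound 4 (1.46 log units; beyond the scatter). This position is therefore sensitive to substitution: one added methyl on this nitrogen is enough for a large step. No measurement at hand accounts for the size of this step.

Open, on these data alone, is how an unsubstituted amino group, an ethylamino group or a ring amine such as pyrrolidine would read at this place with the amide of compound 1 kept. Also open, as far as these compounds go, is whether the same step would appear with the amide of compound 3.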